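The source may report more compounds than this note shows. Statements on the series, on what has been measured and on what is new or still open speak of the compounds shown alone.

Of the compounds shown here, three built on one shared core have been tested in an ADME assay on THP-1 cells (Homo sapiens) for cytotoxicity; a higher number here means that more compound is tolerated, a lower number that less compound is tolerated. Compound 1 `COc1ccc(-n2cc(COc3ccc(/C=N/Nc4nc(-c5cc6cccc(OC)c6oc5=O)cs4)cc3)nn2)cc1` gives 34500 nM. Compound 2 `COc1ccc(-n2cc(COc3ccc(/C=N/Nc4nc(-c5cc6ccccc6oc5=O)cs4)cc3)nn2)cc1` gives 36300 nM, and the step of a 1.1-fold higher number from compound 1 to compound 2 (0.02 log units; within the scatter) shows that taking away a methoxy made no difference that can be trusted. Compound 3 `COc1ccc(-n2cc(COc3ccc(/C=N/Nc4nc(-c5ccc(Br)cc5)cs4)cc3)nn2)cc1` gives 35600 nM; the step of a 1.0-fold lower number from compound 2 to compound 3 (0.01 log units; within the scatter) swapped a two-ring group for a single bromophenyl ring and again left the number where it was. On the numbers shown, compound 3 therefore sits among its two neighbours rather than apart from them: compound 2 is nearest and compound 1 furthest, and both gaps are within the scatter.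

Compound 4 `COc1ccc(-n2cc(COc3ccc(/C=N/Nc4nc(-c5ccc(C)cc5)cs4)cc3)nn2)cc1` is the next step. methyl in place of bromo on an aromatic carbon This is a far smaller change than either measured step, each of which removed or exchanged a larger group elsewhere in the molecule without moving the read-out beyond the scatter. Nothing in the three measured compounds points to a direction for this swap. The expected step is therefore none beyond the scatter, a 1.0-fold lower number from compound 3 to compound 4 (0.01 log units; within the scatter). Compound 4 is estimated at 35000 nM, with a range from 20000 nM to 60000 nM.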

Compound 4, half-maximal cytotoxic concentration: 40300 nM
Estimate against measurement, compound 4: 1.2-fold (0.06 log units) below, and the stated range covers the measured number.
By their numbers in this assay, from the lowest: compounds 1, 3, 2 and 4 (each within the scatter of the next).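

In this assay, exchanging bromo for methyl on the aromatic carbon para to a large group gives a 1.1-fold higher number from compound 3 to compound 4 (0.05 log units; within the scatter), the first direct test of this position, and it shows that these two groups cannot be told apart here. Setting the 4-methylphenyl group in place of the two-ring group gives a 1.1-fold higher number from compound 2 to compound 4 (0.05 log units; within the scatter), so a second single-ring group now stands level with that larger group, where earlier only the 4-bromophenyl group had been compared with it. The data shown offer no measurement that explains this flat result.

On these data alone, only bromo and methyl have been seen at this position, and both are single-atom groups with no hydrogen-bond donors or acceptors and no net charge, so it remains open whether an amine, a carboxylic acid or a longer chain there would move the number beyond the scatter. As far as these compounds go, it also remains open whether any change to the shared core itself, rather than to the groups compared so far, would alter how much compound the cells tolerate.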